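Replacing trifluoromethyl in compound 3: working notes

A few compounds are considered here, and "the series" means these few. Any claim that something is new, unique, unknown or untested is made for them only; others in the source may bear on it.

Measured in a physicochemical assay for solubility, measured as kinetic solubility; a lower number here means a less soluble compound, a higher number a more soluble compound:
- compound 1 `COc1cc(-c2noc([C@H](C)NC(=O)c3cc(C(F)(F)F)nn3C)n2)ccn1`: 156000 nM
- compound 2 `C[C@H](NC(=O)c1cc(C(F)(F)F)nn1C)c1nc(-c2ccnc(N3CCCC3)c2)no1`: 41000 nM
- compound 3 `C[C@H](NC(=O)c1cc(C(F)(F)F)nn1C)c1nc(-c2ccnc(C(F)(F)F)c2)no1`: 58000 nM

Compound 3, at 58000 nM, cannot be separated from the pyrrolidin-1-yl member of the series, as the measured gap is a 1.4-fold higher number from compound 2 to compound 3 (0.15 log units; within the scatter). The methoxy member stands clear of it, with a 2.7-fold lower number from compound 1 to compound 3 (0.43 log units; beyond the scatter).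

The next change puts 1-methoxy-1-methylethyl in place of trifluoromethyl on an aromatic carbon, next to the ring nitrogen, and gives compound 4 `COC(C)(C)c1cc(-c2noc([C@H](C)NC(=O)c3cc(C(F)(F)F)nn3C)n2)ccn1`. The counted difference is 1-methoxy-1-methylethyl in place of trifluoromethyl on an aromatic carbon.

For the measured compounds named here, no measured step makes this exchange. Going by the values given here, the only evidence is the set of changes at the same carbon. The largest of these is a 3.8-fold lower number from compound 1 to compound 2 (0.58 log units; beyond the scatter), and it counts as modest. The replacement of pyrrolidin-1-yl by trifluoromethyl stayed within the scatter. Among the compounds with values here, with only three compounds this supports no rule for the new group, so a small step, if anything slightly upward, is the working expectation, and none beyond the scatter is anticipated. The expected step is a 1.3-fold higher number from compound 3 to compound 4 (0.11 log units; within the scatter). For compound 4 the estimated value is 75000 nM, with an expected range of 30000 nM to 170000 nM.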

Compound 4, solubility: 123000 nM
For compound 4 the middle estimate is 1.6-fold (0.21 log units) below the measured one, and the stated range covers the measured number.
By their numbers in this assay, from the lowest: compounds 2 and 3 (each within the scatter of the next); then compounds 4 and 1 (each within the scatter of the next).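

In this assay the four compounds now fall into two groups at this carbon: 1-methoxy-1-methylethyl stands clear of trifluoromethyl, with a 2.1-fold higher number from compound 3 to compound 4 (0.33 log units; beyond the scatter) as the step, and clear of pyrrolidin-1-yl, with a 3.0-fold higher number from compound 2 to compound 4 (0.48 log units; beyond the scatter) as the step. For the compounds shown here, until now methoxy was the only group standing apart from the others, but it cannot be separated from the new group, as the gap is a 1.3-fold lower number from compound 1 to compound 4 (0.10 log units; within the scatter) and so no order can be given between the two. Among these four compounds, with none going against it, the two groups carrying an oxygen form one pair and the two without oxygen form the other, although nothing measured on these compounds explains that split.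

The compounds shown leave open whether a hydroxyl-bearing group such as 1-hydroxy-1-methylethyl, or a longer ether chain such as 2-methoxyethyl, would join compounds 1 and 4 at this carbon. They also leave open where a primary amine or a carboxylic acid would fall, and whether the pairing would survive a larger set of groups.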